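From cyclopropylmethyl to cyclobutyl on the amine nitrogen

This account rests on a few compounds, and the source may have more. Where it says the series, first, only, none or still open, it means among the compounds named here.

Measured in an ADME assay on Caco-2 cells (Homo sapiens) for permeability, read by LC-MS, with a stated time of 2 h; a lower number here means that the compound crosses the layer more slowly, a higher number that the compound crosses the layer faster:
compound 1 `Cc1cc(CN(C2CCC2)C(CC(=O)O)c2ccc(Cl)cc2)ccc1OCCn1c(=O)ccn(C)c1=O`: 5 nm/s
compound 2 `CCCN(Cc1ccc(OCCn2c(=O)ccn(C)c2=O)c(OC)c1)C(CC(=O)O)c1ccc(Cl)cc1`: 1 nm/s
compound 3 `COc1cc(CN(CC2CC2)C(CC(=O)O)c2ccc(Cl)cc2)ccc1OCCn1c(=O)ccn(C)c1=O`: 0.8 nm/s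

Compound 3, at 0.8 nm/s, stands at the low end of this small set, within the scatter of compound 2, while compound 1 lies higher than compound 3 by more than the scatter.

Compound 4 `COc1cc(CN(C2CCC2)C(CC(=O)O)c2ccc(Cl)cc2)ccc1OCCn1c(=O)ccn(C)c1=O` has the same atoms as compound 3, joined differently: cyclobutyl in place of cyclopropylmethyl on an amine nitrogen. Among the measured compounds shown here, one measured step touches the group on this amine nitrogen, a 1.3-fold lower number from compound 2 to compound 3 (0.10 log units; within the scatter), and it stays within the scatter. For the measured compounds named here, compound 1, the only measured compound with cyclobutyl on an amine nitrogen, gives 5 nm/s in this assay, but no measured step isolates that group. A small rise is therefore expected, one that does not clearly leave the scatter. The expected step is a 1.9-fold higher number from compound 3 to compound 4 (0.27 log units; within the scatter). Compound 4 is estimated at 1.5 nm/s, with an expected range of 0.6 nm/s to 4 nm/s.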

Compound 4, apparent permeability: 1.7 nm/s
Compound 4: middle estimate off by 1.1-fold (0.05 log units), on the low side, within the range that was stated.
By their numbers in this assay, from the lowest: compounds 3, 2 and 4 (each within the scatter of the next, the first and the last beyond it); then compound 1.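

In this assay the swap of cyclopropylmethyl for cyclobutyl on the amine nitrogen is a readable step, a 2.1-fold higher number from compound 3 to compound 4 (0.33 log units; beyond the scatter) and so modest but just beyond the scatter, whereas the change from propyl, a 1.7-fold higher number from compound 2 to compound 4 (0.23 log units; within the scatter) stays within it. Compound 4 also isolates methoxy against methyl on an aromatic carbon, giving a 2.9-fold lower number from compound 1 to compound 4 (0.47 log units; beyond the scatter) and again a modest step beyond the scatter, so cyclobutyl on the amine nitrogen does not by itself carry the number of compound 1. Nothing given here accounts for either step.

Whether the cyclobutyl step holds with methyl in place of methoxy on that aromatic carbon stays open, as no cyclopropylmethyl partner of compound 1 is shown. A larger ring such as cyclopentyl on the amine nitrogen, or an ester in place of the carboxylic acid, also lies outside the compounds shown.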